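Swapping a Five-Membered Ring on a Shared Core

The compounds below may be only part of what the source reports. "The series", "measured", "known", "first", "only" and "open" are said of these compounds alone.

Three compounds share one core and differ only in a five-membered aromatic ring attached to it. Compound 1 `c1coc(-c2ccccc2OCC2=NCCN2)c1` carries furan-2-yl, compound 2 `c1csc(-c2ccccc2OCC2=NCCN2)c1` thiophen-2-yl and compound 3 `c1ccc(-c2ccsc2)c(OCC2=NCCN2)c1` thiophen-3-yl. In a functional assay for activation of Alpha-1B adrenergic receptor (Homo sapiens), read by calcium flux (on this read-out lower numbers stand for smaller maximal responses and higher numbers for larger maximal responses), compound 1 gives 110%, compound 2 gives 112% and compound 3 gives 103%. The change from compound 1 to compound 2 gave a number 2 percentage points higher from compound 1 to compound 2 (within the scatter), from compound 1 to compound 3 a number 7 percentage points lower from compound 1 to compound 3 (within the scatter) and from compound 2 to compound 3 a number 9 percentage points lower from compound 2 to compound 3 (within the scatter). Compound 3 thus stands at the lower end of three numbers that all lie within the scatter of one another, so none of them can be called different from the others.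

Compound 4 `c1ccc(-c2cc[nH]n2)c(OCC2=NCCN2)c1` makes one further change at the same place: 1H-pyrazol-3-yl in place of thiophen-3-yl on an aromatic carbon. Within the data shown here, no measured step covers a ring with two hetero atoms or a hydrogen-bond donor, so the three ring swaps seen so far are the only guide, and each of them left the maximal response unchanged within the scatter. The expectation for compound 4 is therefore a step of a number 1 percentage points lower from compound 3 to compound 4 (within the scatter), no larger than the scatter, with a wider range to allow for the untested donor. For compound 4 the estimated value in this assay is 102%, between 78% and 120%.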

Compound 4, largest response reached (reported as maximum), in percent of the reference or control that the assay uses: 39%
Beside the measured number, compound 4's estimate is 63 percentage points above it; the measured number lies below the stated range.
By their numbers in this assay, from the lowest: compound 4; then compounds 3, 1 and 2 (each within the scatter of the next).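

This position proves less forgiving than the first three compounds suggested: in this assay the furan-2-yl, thiophen-2-yl and thiophen-3-yl rings cannot be told apart, yet 1H-pyrazol-3-yl gives a number 64 percentage points lower from compound 3 to compound 4 (beyond the scatter) and the same picture against the other two rings, with a number 73 percentage points lower from compound 2 to compound 4 (beyond the scatter) and a number 71 percentage points lower from compound 1 to compound 4 (beyond the scatter) as the result. Ring size alone therefore does not decide the maximal response, since the entering and leaving groups are both five-membered aromatic rings with the same number of heavy atoms, and they differ instead in a second hetero atom, in nitrogen taking the place of sulfur, and in a hydrogen-bond donor. Nothing available here shows which of these differences accounts for the loss of response.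

The compounds shown leave open whether the hydrogen on the ring nitrogen or the pair of ring nitrogens is what matters, a question that a pyrazole with a methyl group on that nitrogen, or a thiazole ring, could help to separate. They also leave open how a six-membered ring such as pyridine, or an open-chain group such as an amine, would behave at this place.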